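The source may report more compounds than this note shows. Statements on the series, on what has been measured and on what is new or still open speak of the compounds shown alone.

Measured so far:
- compound 1 `N#Cc1ccc(Oc2cccc(NS(=O)(=O)c3cccc(C(F)(F)F)c3)c2)cc1`: 2200 nM
- compound 2 `Nc1ccc(Oc2cccc(NS(=O)(=O)c3cccc(C(F)(F)F)c3)c2)cc1N`: > 15000 nM

Of the compounds shown here, two have been tested in a functional assay on PLC5 cells (Homo sapiens) for inhibition, read by MTT assay, with a stated time of 24 h; on this read-out lower numbers stand for stronger inhibition and higher numbers for weaker inhibition. For compound 2 the result is only a limit of the assay, > 15000 nM, and no exact number. Within the data shown here, the one measured step, an at least 6.8-fold higher number from compound 1 to compound 2 (0.83 log units; beyond the scatter), is itself only a bound because of the limit of > 15000 nM in this assay, at which 1 of the 2 values shown sits. Compound 3 `O=c1[nH]c2ccc(Oc3cccc(NS(=O)(=O)c4cccc(C(F)(F)F)c4)c3)cc2[nH]1` is not yet measured. It differs from compound 2 in the change (a group of 10 heavy atoms (7 carbon, 2 nitrogen, 1 oxygen; one five-membered aromatic ring with 2 hetero atoms, one six-membered aromatic ring of carbon only) in place of a group of 8 heavy atoms (6 carbon, 2 nitrogen; one six-membered aromatic ring of carbon only), on an oxygen on an aromatic ring). Among the measured compounds shown here, no measured step covers this change, and only the weak position of compound 2 and the stronger position of compound 1 set the frame. For the measured compounds named here, since the group entering compound 3 is neither the one in compound 1 nor the one in compound 2, its number is expected to lie between them, with wide uncertainty. Compound 3 is estimated at 8000 nM, within 2000 nM to 30000 nM. That estimate corresponds to an expected at least 1.8-fold lower number from compound 2 to compound 3 (0.27 log units; that floor lies within the scatter).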

Compound 3, half-maximal inhibitory concentration: 11500 nM
Compound 3: the middle estimate sits 1.4-fold (0.16 log units) below what was measured, and the stated range covers the measured number.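

In this assay, replacing the 4-cyanophenyl group on this oxygen with a group of one five-membered and one six-membered aromatic ring gives a 5.2-fold higher number from compound 1 to compound 3 (0.72 log units; beyond the scatter), so a second group besides 3,4-diaminophenyl now reads weaker than 4-cyanophenyl. Compound 2 has only a limit of the assay, > 15000 nM. The step to the new group is an at least 1.3-fold lower number from compound 2 to compound 3 (0.11 log units; that floor lies within the scatter), and no order between these two can be claimed, because that step is only a bound: the limit of > 15000 nM in this assay, at which 1 of the 3 values shown sits.

Going by these compounds, it remains open whether the nitrile itself carries the stronger reading, which a plain phenyl ring or a phenyl ring bearing a carboxylic acid at this place could test. Also open, on these data alone, is whether the order holds when the trifluoromethyl group is exchanged for another group, such as a methyl group.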